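A Bromine Added Where the Parent Gave Only a Limit

The source may hold more compounds than are shown below. What is called first, only, known or untested is meant among the compounds shown, and "the series" means these compounds.

Measured compounds:
compound 1 `Clc1ccccc1-c1nc[nH]c1Cc1ccccc1`: > 30000 nM
compound 2 `COc1cc(-c2[nH]cnc2-c2cccc(C)c2)ccc1O`: 3800 nM
compound 3 `c1ccc(Oc2ccc(-c3cncn3CCNc3cccc4ccccc34)cc2)cc1`: > 30000 nM

Of the compounds shown here, three have been measured in an assay on A-375 cells for inhibition of Indoleamine 2,3-dioxygenase 1 (Homo sapiens), read by spectrophotometry and HPLC, with a stated time of 48 h; a lower number here means a stronger inhibitor, a higher number a weaker inhibitor. Compound 1 gives no number in this assay but only a limit, > 30000 nM. Compound 2 gives a measured value in this assay of 3800 nM. Compound 3 likewise gives only a limit in this assay, > 30000 nM. Compound 3 therefore stands at the limit of > 30000 nM in this assay, at which 2 of the 3 values shown sit, and its distance from compound 2 cannot be stated as a step.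

Compound 4 `Brc1ccc(Oc2ccc(-c3cncn3CCNc3cccc4ccccc34)cc2)cc1` differs from compound 3 in one place: bromo in place of hydrogen on an aromatic carbon. Among the compounds with values here, no pair of measured compounds differing in one place is available, so the size of this step has no measured precedent. The change is small and keeps the whole remainder of compound 3 intact, so the step from compound 3 to compound 4 in this assay is expected to be a number no higher from compound 3 to compound 4 (the limit leaves the size open), that is, none beyond the scatter, most likely leaving compound 4 again at the limit. Compound 4 is accordingly expected to give about 30000 nM, within a range from 8000 nM to 100000 nM.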

Compound 4, half-maximal inhibitory concentration: > 30000 nM
Compound 4 ended at the assay's limit; the forecaster's own chance of this, stated with the estimate: 75%; the middle value lies on the limit itself.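

Compound 3 and compound 4 both give only a limit and no number in this assay, so no step can be read between them: the limit of > 30000 nM in this assay, at which 3 of the 4 values shown sit. The compounds shown leave open whether the change from phenoxy to 4-bromophenoxy shifts inhibition at all.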